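Replacing the 2-oxopyrrolidin-1-yl group of compound 3

The source may hold more compounds than are shown below. What is called first, only, known or untested is meant among the compounds shown, and "the series" means these compounds.

In a physicochemical assay for solubility, read by LC-MS, in phosphate buffer, with a stated time of 24 h, at pH 7.4 (a higher number here means a more soluble compound, a lower number a less soluble compound), compound 1 `Cc1ncccc1-c1cnc(NCc2c(F)ccc3c2CCO3)c2nn(CC#N)c(=O)n12` gives 4000 nM. Compound 2 `Cn1nccc1-c1cnc(NCc2c(F)ccc3c2CCO3)c2cn[nH]c(=O)c12` gives 2000 nM. Compound 3 `O=C1CCCN1c1cnc(NCc2c(F)ccc3c2CCO3)c2cn[nH]c(=O)c12` stands at < 2000 nM, and this is a limit, not a number.

Compound 4 `Cc1nc(CN(C)C)ccc1-c1cnc(NCc2c(F)ccc3c2CCO3)c2cn[nH]c(=O)c12` has not yet been measured. It keeps the core of compound 3 and changes one group on an aromatic carbon, where 6-((dimethylamino)methyl)-2-methylpyridin-3-yl takes the place of 2-oxopyrrolidin-1-yl: 6-((dimethylamino)methyl)-2-methylpyridin-3-yl in place of 2-oxopyrrolidin-1-yl on an aromatic carbon.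

Going by the values given here, only one measured step touches this position, and it is a number no higher from compound 2 to compound 3 (the limit leaves the size open). That step ends at a limit, so it offers a direction but no size. Read in reverse, it suggests that swapping 2-oxopyrrolidin-1-yl for an aromatic ring need not lower the number, since compound 2 carries 1-methyl-1H-pyrazol-5-yl there and gives 2000 nM. The group entering compound 4 has no measured neighbour, so any size remains a broad judgement.

The expected step is upward and beyond the scatter, an at least 5.0-fold higher number from compound 3 to compound 4 (0.69 log units; beyond the scatter). The estimate for compound 4 is 10000 nM, with an expected range from 2000 nM to 60000 nM.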

Compound 4, solubility: > 1000000 nM
Compound 4: only a limit was reported; the forecaster's own chance of this, stated with the estimate: 20%; middle value at least 100-fold (2.00 log units) from the limit.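

In this assay, this position on the six-membered aromatic ring can carry a very large change: putting 6-((dimethylamino)methyl)-2-methylpyridin-3-yl in place of 2-oxopyrrolidin-1-yl gives an at least 500-fold higher number from compound 3 to compound 4 (2.69 log units; beyond the scatter). Compound 2 already carries an aromatic ring here, yet putting the same group in place of its 1-methyl-1H-pyrazol-5-yl gives an at least 500-fold higher number from compound 2 to compound 4 (2.69 log units; beyond the scatter), so an aromatic ring at this place is not enough on its own to reach the result of compound 4. The result for compound 4 is a limit and not a number, so the full size of both steps stays open: the limit of > 1000000 nM in this assay, at which 1 of the 4 values shown sits.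

The entering group differs from both earlier groups in several features at once, so the compounds shown cannot separate the dimethylamino group, the ring methyl and the pyridine ring from one another. A plain 2-methylpyridin-3-yl without the side chain would test the ring alone, while a morpholine or a carboxylic acid on the same one-carbon arm would test whether the dimethylamino group itself is needed for a result of this size.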